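This account rests on a few compounds, and the source may have more. Where it says the series, first, only, none or still open, it means among the compounds named here.

Measured so far:
- Compound 1 `Cc1ccc2oc(/C=C/[S+](C)[O-])cc(=O)c2c1` gives 1700 nM in a functional assay on A549 cells (Homo sapiens) for cytotoxicity, with a stated time of 48 h; a lower number here means a stronger inhibitor, a higher number a weaker inhibitor
- Compound 2 `COc1cccc2oc(/C=C/[S+](C)[O-])cc(=O)c12` gives 3800 nM in this assay

Compound 1 has the lowest number of the two in this assay; compound 2 sits at a higher number, and that gap lies beyond the usual scatter of the assay. Going by the values given here, no pair of these measured compounds differs in only one place, so no single step has yet been isolated from the data.

Compound 3 `C[S+]([O-])/C=C/c1cc(=O)c2cc(Br)ccc2o1` is not yet measured. It differs from compound 1 in one place: bromo in place of methyl on an aromatic carbon. Among the compounds with values here, with no comparable step among the measured compounds, the expectation rests on compound 1 alone, and a step of no more than modest size in either direction is expected. For compound 3 the estimated outcome in this assay is 1500 nM, within a range from 600 nM to 4000 nM, which means an expected step of a 1.1-fold lower number from compound 1 to compound 3 (0.05 log units; within the scatter) that stays close to the scatter.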

Compound 3, half-maximal inhibitory concentration: 1100 nM
Compound 3: middle estimate off by 1.4-fold (0.13 log units), on the high side; the measured number falls inside the stated range.
By their numbers in this assay, from the lowest: compounds 3 and 1 (each within the scatter of the next); then compound 2.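

Bromo in place of methyl on this aromatic carbon is the first change in the set that can be read on its own, and in this assay it gives a 1.5-fold lower number from compound 1 to compound 3 (0.19 log units; within the scatter) as the step. The two groups therefore cannot be told apart at this position in this assay, and bromo is tolerated here with cytotoxicity retained. This says nothing about why, as no measurement is at hand that could explain the result.

Methyl and bromo are only two groups, so it remains open whether an amine, a carboxylic acid or a longer chain on this carbon would shift the number beyond the scatter. Compound 2 differs from compound 1 and compound 3 in more than one place, so it offers no reading of this position.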